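Cyanoguanidine chain homologues: ethyl against isopropyl at the amine

The source may hold more compounds than are shown below. What is called first, only, known or untested is meant among the compounds shown, and "the series" means these compounds.

Compound 1 `CCN/C(=N\C#N)NCCCCc1c[nH]cn1` and compound 2 `CC(C)N/C(=N\C#N)NCCCCc1c[nH]cn1` carry the shorter four-carbon chain, compound 3 `CCN/C(=N/C#N)NCCCCCc1c[nH]cn1` and compound 4 `CC(C)N/C(=N/C#N)NCCCCCc1c[nH]cn1` the longer one. In an in vitro functional assay on Sf9 cells for antagonist activity at histamine H2 receptor (Homo sapiens) (a higher number here means a more potent compound, by a factor of ten per unit of this negative logarithm, a lower number a less potent compound), compound 1 gives < 5, which is a limit of the assay and not a number. In this assay compound 2 likewise gives < 5, again a limit rather than a number. For the measured compounds named here, compound 3 is the only member with a read number: in this assay compound 3 gives 5.37. The difference between the core of compound 1 and the core of compound 3 is not broken down here.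

The change from compound 1 to compound 2 is methyl in place of hydrogen on a saturated chain carbon bound to an amine nitrogen and a saturated chain carbon. Its size, a step that the two limits leave unreadable from compound 1 to compound 2, cannot be read because the limit of < 5 in this assay, at which 2 of the 3 values shown sit, covers both ends. The change from compound 3 to compound 4 is methyl in place of hydrogen on a saturated chain carbon bound to an amine nitrogen and a saturated chain carbon, the same change at the same place, now made on the longer chain where one end is a number.

Going by the values given here, nothing measured fixes the size of the step from compound 3 to compound 4; the only comparable pair is unreadable. The expectation is therefore a step of about zero, a number 0.07 log units lower from compound 3 to compound 4 (within the scatter), with wide uncertainty. Compound 4 is accordingly estimated at 5.3 in this assay, expected to fall between 4.6 and 6.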

Compound 4, negative logarithm of the antagonist equilibrium constant: 5.57
For compound 4 the middle estimate is 0.27 log units below the measured one; low and high end bracket the measured number.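

In this assay, methyl in place of hydrogen on the saturated chain carbon bound to the amine nitrogen, read on the longer chain, gives a number 0.20 log units higher from compound 3 to compound 4 (within the scatter), so on this core ethylamino and isopropylamino cannot be told apart in this read-out. The same change on the shorter chain, from compound 1 to compound 2, cannot be read, so no second size exists to set against this one, because both ends of that pair rest on a limit and not on a number: the limit of < 5 in this assay, at which 2 of the 4 values shown sit. The result therefore shows a single readable step on a single core; it neither confirms nor contradicts that the change carries over from one core to another, and it says nothing about the size of the step on the core of compound 1.

The compounds shown leave open how this read-out responds to other groups on the amine nitrogen, such as tert-butyl or cyclohexyl, in place of ethyl and isopropyl. Also open, going by these compounds, is how the ethylamino and isopropylamino pair reads on a longer chain than that of compound 3 and compound 4.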